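From Fluorophenyl to Chlorophenyl in a Seizure Model

The compounds below may be only part of what the source reports. "The series", "measured", "known", "first", "only" and "open" are said of these compounds alone.

Compound 1, `CC(C(=O)N1CCN(c2ccc(F)cc2)CC1)N1C(=O)CCC1=O`: 0%
Compound 2, `CCC(C(=O)N1CCN(c2cccc(C)c2)CC1)N1C(=O)CCC1=O`: 0%

In a functional assay on the whole organism (strain Swiss) with Mus musculus as the target, in the maximal electroshock model, with a stated time of 0.5 h, at a dose of 100 mg/kg by the intraperitoneal route (on this read-out lower numbers stand for a weaker effect and higher numbers for a stronger effect at the one dose given), compound 1 gives 0%, and compound 2 gives 0%; the two values lie level with each other, within the usual scatter. Compound 3, `CC(C(=O)N1CCN(c2cccc(Cl)c2)CC1)N1C(=O)CCC1=O`, differs from compound 1 by 3-chlorophenyl in place of 4-fluorophenyl on an amine nitrogen in a ring. Among the compounds with values here, no step between measured compounds is available, and both measured compounds show no protection at the digits given. The step of a number 5 percentage points higher from compound 1 to compound 3 (within the scatter) is therefore expected to be none beyond the scatter. Compound 3 is expected to give 5%, with a range from 0% to 30%.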

Compound 3, a percentage reported as activity, at one dose (the size of the read-out at that dose, not a potency): 75%
Compound 3: middle estimate off by 70 percentage points, on the low side; measured number above the stated range.
By their numbers in this assay, from the lowest: compounds 1 and 2 (each within the scatter of the next); then compound 3.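

In this assay, the group on this amine nitrogen in a ring can decide the outcome: 3-chlorophenyl in place of 4-fluorophenyl gives a number 75 percentage points higher from compound 1 to compound 3 (beyond the scatter). The two earlier level values could not show that this position responds so strongly. Nothing measured here explains the step. The change alters both the halogen and its place on the phenyl ring, so the compounds shown leave open which of the two matters. A 4-chlorophenyl or a 3-fluorophenyl group at this position would separate them.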